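A few compounds are considered here, and "the series" means these few. Any claim that something is new, unique, unknown or untested is made for them only; others in the source may bear on it.

Among the compounds with values here, in an ADME assay on microsomes from liver (Rattus norvegicus) for metabolic stability, with a stated time of 10 min (a higher number here means that more of the compound is left, a lower number that less of the compound is left), compound 1 (`CCSc1nn2cc(-c3cc4ccccc4o3)nc2s1`) gives 35% and has only one measured compound to be compared with. Compound 2 (`COc1nn2cc(-c3cc4c(OC)ccc(OC)c4o3)nc2s1`) gives 28% in this assay and so lies within the usual scatter of compound 1, which means the two cannot be told apart on these numbers. Compound 3 (`c1ccc2oc(-c3cn4nc(C5CC5)sc4n3)cc2c1`) has not yet been measured. It keeps the core of compound 1 but carries cyclopropyl in place of ethylsulfanyl on an aromatic carbon. Within the data shown here, no measured pair shows this exchange, so the data give no firm guide to its size or direction, and the expectation is for no step beyond the scatter. An expected a number 2 percentage points higher from compound 1 to compound 3 (within the scatter) would stay within that scatter. Compound 3 is expected to show 37% (estimated range 18% to 60%).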

Compound 3, percent of the compound remaining: 53%
Compound 3: middle estimate off by 16 percentage points, on the low side, within the range that was stated.
By their numbers in this assay, from the lowest: compounds 2 and 1 (each within the scatter of the next); then compound 3.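

In this assay the exchange of ethylsulfanyl for cyclopropyl on this aromatic carbon gives a number 18 percentage points higher from compound 1 to compound 3 (beyond the scatter) and thereby shows that the group at this position can shift the result by more than the usual scatter. The two groups have the same count of 3 heavy atoms, yet sulfur leaves and a three-membered ring of carbon enters, so a step beyond the scatter is possible without a change in that count. Nothing measured here explains the step.

This is a single pair, so the loss of sulfur and the gain of a ring cannot be told apart, and a propyl chain at this position, with carbon only and no ring, would separate the two. On these data alone, how an amine at the same position would compare also remains open.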